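Aminochromene spiro-oxindoles with triazolylmethyl groups on HCT-116 cells

A few compounds are considered here, and "the series" means these few. Any claim that something is new, unique, unknown or untested is made for them only; others in the source may bear on it.

Measured so far:
Compound 1 `N#CC1=C(N)Oc2c(c3nc4ccccc4nc3c3ccccc23)C12C(=O)N(Cc1cnnn1-c1ccc(F)cc1)c1ccccc12` — in a functional assay on HCT-116 cells (Homo sapiens) for antiproliferative activity, read by MTT assay, with a stated time of 48 h (on this read-out lower numbers stand for stronger inhibition and higher numbers for weaker inhibition), a limit only, > 50000 nM.
Compound 2 `N#CC1=C(N)Oc2c(N)cc3nc4ccccc4nc3c2C12C(=O)N(Cc1cnnn1-c1ccc(Cl)cc1)c1ccccc12` — in this assay a limit only, > 50000 nM.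

Compound 2 stands at the limit, as does the other measured compound: the limit of > 50000 nM in this assay, at which 2 of the 2 values shown sit. Compound 3 `Cc1ccc(-n2nncc2CN2C(=O)C3(C(C#N)=C(N)Oc4c(N)cc5nc6ccccc6nc5c43)c3ccccc32)cc1C` is the next step; the change is 3,4-dimethylphenyl in place of 4-chlorophenyl on an aromatic nitrogen. With both measured values sitting at the limit, no move beyond the scatter is expected from compound 2 to compound 3; the expected step is a number no higher from compound 2 to compound 3 (the limit leaves the size open). Compound 3 is therefore estimated at 50000 nM in this assay, with a range of 15000 nM to 150000 nM, and most likely again only a limit.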

Compound 3, half-maximal inhibitory concentration: > 50000 nM
Compound 3 gave a limit, no number; the forecaster's own chance of this, stated with the estimate: 75%; the middle value lies on the limit itself.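

No step can be read from compound 2 to compound 3, as both give only a limit and no number: the limit of > 50000 nM in this assay, at which 3 of the 3 values shown sit.

The compounds shown leave open whether 3,4-dimethylphenyl and 4-chlorophenyl on the aromatic nitrogen differ at all in this read-out.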